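A few compounds are considered here, and "the series" means these few. Any claim that something is new, unique, unknown or untested is made for them only; others in the source may bear on it.

Compound 1 `CN1CCN(CCCN(C(=O)Nc2ccc(F)c(Cl)c2)C2CCc3ccc(S(=O)(=O)N(C)C)cc3C2)CC1` gives 3000 nM in an assay on CHO cells for binding affinity to melanin-concentrating hormone receptor 1 (Homo sapiens); on this read-out lower numbers stand for stronger inhibition and higher numbers for weaker inhibition.
Compound 2 `CC(=O)Nc1ccc2c(c1)CC(N(CCCN1CCN(C)CC1)C(=O)Nc1ccc(F)c(Cl)c1)CC2` gives 6 nM.
Compound 3 `CC(C)C(=O)Nc1ccc2c(c1)CC(N(CCCN1CCN(C)CC1)C(=O)Nc1ccc(F)c(Cl)c1)CC2` gives 61 nM.

On these numbers compound 3 holds the second highest of the three. Its nearest neighbour is compound 2, reached through the step of a 10-fold higher number from compound 2 to compound 3 (1.01 log units; beyond the scatter), in which isopropyl in place of methyl brought the higher number. Compound 1 lies furthest away, as the step of a 49-fold lower number from compound 1 to compound 3 (1.69 log units; beyond the scatter) shows. Compound 4 `CCNC(=O)Nc1ccc2c(c1)CC(N(CCCN1CCN(C)CC1)C(=O)Nc1ccc(F)c(Cl)c1)CC2` has not been measured. It differs from compound 3 in one place: ethylamino in place of isopropyl on a carbonyl carbon. Among the compounds with values here, the entering group matches the leaving one in count of heavy atoms but brings a hydrogen-bond donor, and no measured step covers such a swap. Within the data shown here, the only step on the same carbonyl carbon is the one between compound 2 and compound 3, where growth from methyl to isopropyl raised the number. Ethylamino is no larger than isopropyl, so no step beyond the scatter is expected, with a slight lean toward a lower number. The expected step is a 1.7-fold lower number from compound 3 to compound 4 (0.24 log units; within the scatter). Compound 4 is therefore estimated at 35 nM, ranging from 7 nM to 170 nM.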

Compound 4, inhibition constant: 160 nM
Compound 4: middle estimate off by 4.6-fold (0.66 log units), on the low side; measured number inside the range.
By their numbers in this assay, from the lowest: compound 2; then compound 3; then compound 4; then compound 1.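

Ethylamino matches isopropyl in heavy-atom count, yet in this assay the number still rose (a 2.6-fold higher number from compound 3 to compound 4 (0.42 log units; beyond the scatter)), so on this carbonyl carbon heavy-atom count alone does not set the result, and a nitrogen carrying a hydrogen-bond donor in the chain is not a neutral exchange. Among the three groups now seen on this carbon, methyl gives the lowest number and ethylamino the highest (a 27-fold higher number from compound 2 to compound 4 (1.43 log units; beyond the scatter)), although the (ethylcarbamoyl)amino group still beats dimethylsulfamoyl on the aromatic carbon by a wide margin (a 19-fold lower number from compound 1 to compound 4 (1.27 log units; beyond the scatter)). No measurement here explains why ethylamino behaves this way.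

On these data alone, whether methylamino or a plain amino group on the same carbonyl carbon would bring the number back toward that of compound 2 stays open. So does whether ethoxy, with oxygen in place of the nitrogen, would separate the effect of the amide hydrogen from that of chain length.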